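A few compounds are considered here, and "the series" means these few. Any claim that something is new, unique, unknown or untested is made for them only; others in the source may bear on it.

- Compound 1 `CNC(=O)[C@@H]1CC[C@H](c2ccc(OCc3ccccc3F)cc2)N1` gives 9.3 mL.min-1.g-1
- Compound 2 `N#Cc1ccccc1COc1ccc([C@H]2CC[C@@H](C(N)=O)N2)cc1` gives 1.4 mL.min-1.g-1

In an ADME assay on microsomes from liver (Rattus norvegicus) for metabolic stability (a lower number here means slower removal, a higher number faster removal of the compound), compound 2 has the lower of the two numbers (1.4 mL.min-1.g-1), and its gap to compound 1 lies beyond the usual scatter. Compound 3 `N#Cc1ccc(COc2ccc([C@H]3CC[C@@H](C(N)=O)N3)cc2)cc1` has the same atoms as compound 2, joined differently: 4-cyanophenyl in place of 2-cyanophenyl on a saturated chain carbon bound to an oxygen on an aromatic ring. Going by the values given here, no measured pair shows what such a move does, so only a small rise, within the scatter, is expected (a 1.4-fold higher number from compound 2 to compound 3 (0.15 log units; within the scatter)). For compound 3 the estimated value is 2 mL.min-1.g-1, with an expected range from 0.9 mL.min-1.g-1 to 5 mL.min-1.g-1.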

Compound 3, intrinsic clearance in microsomes: 0.6 mL.min-1.g-1
Compound 3: middle estimate off by 3.3-fold (0.52 log units), on the high side; the measured number lies below the stated range.
By their numbers in this assay, from the lowest: compound 3; then compound 2; then compound 1.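

Compounds 2 and 3 contain the same atoms, so this pair isolates where the nitrile sits on the ring. In this assay, 4-cyanophenyl in place of 2-cyanophenyl gives a 2.3-fold lower number from compound 2 to compound 3 (0.37 log units; beyond the scatter), a modest change, which shows that this position responds to a shift of the nitrile alone. Nothing available explains this difference. From the compounds shown here alone, whether the nitrile is needed at all remains open, as does how a plain phenyl group or a carboxylic acid in its place would behave in this assay.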